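Phenylsulfanyl for hydroxy on the benzyl ether of compound 2

The compounds below may be only part of what the source reports. "The series", "measured", "known", "first", "only" and "open" are said of these compounds alone.

Compound 2 `COc1cc(OCc2cccc(O)c2)c2cc(-c3cn4nc(OC)sc4n3)oc2c1` stands at the top of the two numbers gathered so far: in an ADME assay on microsomes from liver (Rattus norvegicus) for metabolic stability, with a stated time of 10 min (a higher number here means that more of the compound is left, a lower number that less of the compound is left), compound 2 gives 49%. Among the compounds with values here, its nearest neighbour is compound 1 `COc1cc(OCc2ccccc2OC)c2cc(-c3cn4nc(OC)sc4n3)oc2c1`, which in this assay gives 28%, and the only measured step, a number 21 percentage points higher from compound 1 to compound 2 (beyond the scatter), lies beyond the scatter. Compound 3 `COc1cc(OCc2cccc(Sc3ccccc3)c2)c2cc(-c3cn4nc(OC)sc4n3)oc2c1` differs from compound 2 by phenylsulfanyl in place of hydroxy on an aromatic carbon. Within the data shown here, no measured step covers this change; the step from compound 1 to compound 2 altered the same aromatic ring but exchanged different groups, so it shows only that changes on this ring can move the number by a modest amount, not in which direction this one will. With the hydroxy of compound 2 leaving, compound 3 is expected to fall back toward the level of compound 1 at 28%, and the estimated step is a number 24 percentage points lower from compound 2 to compound 3 (beyond the scatter). For compound 3 the expected value in this assay is 25%, within a range from 8% to 50%.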

Compound 3, percent of the compound remaining: 45%
Beside the measured number, compound 3's estimate is 20 percentage points below it, and the stated range covers the measured number.
By their numbers in this assay, from the lowest: compound 1; then compounds 3 and 2 (each within the scatter of the next).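

In this assay, phenylsulfanyl in place of hydroxy gives a number 4 percentage points lower from compound 2 to compound 3 (within the scatter), so this exchange leaves the read-out indistinguishable from that of the hydroxy compound. The earlier step showed that the number can move when groups on this aromatic ring are exchanged, but it involved different groups and did not test this position alone; here, at the carbon described as meta to a large group, a hydrogen-bond donor leaves and a further six-membered aromatic ring of carbon only enters with no step beyond the scatter. Nothing in the available data explains why the read-out holds across so large a change in the group.

The two compounds do not show whether the sulfur link itself matters, which a phenoxy group or a benzyl group at this position could test against phenylsulfanyl. As far as these compounds go, it also remains open whether this position would accept groups of another kind, such as an amine or a carboxylic acid, with the number staying within the scatter of compound 2 and compound 3.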